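Lengthening the methylpiperazine chain of compound 1

The source may hold more compounds than are shown below. What is called first, only, known or untested is meant among the compounds shown, and "the series" means these compounds.

Measured in a functional assay on A549 cells (Homo sapiens) for cytotoxicity, read by MTT assay, with a stated time of 72 h; on this read-out higher numbers stand for weaker inhibition and lower numbers for stronger inhibition:
- compound 1 `CN1CCN(CCCCn2c3c(c4ccccc42)C(=O)c2c[n+]([O-])c4ccccc4c2C3=O)CC1`: 90 nM
- compound 2 `CC1(C)OC[C@H](Cn2cc(Cn3c4c(c5ccccc53)C(=O)c3c[n+]([O-])c5ccccc5c3C4=O)nn2)O1`: 340 nM
- compound 3 `CC1(C)OC[C@@H](Cn2cc(Cn3c4c(c5ccccc53)C(=O)c3c[n+]([O-])c5ccccc5c3C4=O)nn2)O1`: 4700 nM

Compound 1 gives the lowest number of the three, beyond the scatter of both others. Compound 2 is nearest to it and compound 3 furthest.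

Compound 4 `CN1CCN(CCCCCCn2c3c(c4ccccc42)C(=O)c2c[n+]([O-])c4ccccc4c2C3=O)CC1` keeps the shared core and carries 2-(4-methylpiperazin-1-yl)ethyl in place of 4-methylpiperazin-1-yl, on a saturated chain carbon, four bonds along the chain from an aromatic nitrogen (2-(4-methylpiperazin-1-yl)ethyl in place of 4-methylpiperazin-1-yl on a saturated chain carbon, four bonds along the chain from an aromatic nitrogen).

Going by the values given here, only one measured step is available, a 14-fold higher number from compound 2 to compound 3 (1.14 log units; beyond the scatter). It is a change of configuration alone the fact that compounds 2 and 3 differ only in the configuration as drawn and leaves the chain untouched, so it sets no size for this change. It does show that a change with no new atoms can move the number strongly, which argues for a wide range. Among the compounds with values here, compound 1 is the only measured compound with a methylpiperazine, so no measured step covers chain length. With compound 1 already lowest at 90 nM, a modest rise is expected, not a step clearly beyond the scatter.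

The expected step in this assay is a 1.6-fold higher number from compound 1 to compound 4 (0.19 log units; within the scatter).

For compound 4 the estimated value is 140 nM, with an expected range of 40 nM to 500 nM.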

Compound 4, half-maximal inhibitory concentration: 330 nM
Compound 4: the middle estimate sits 2.4-fold (0.37 log units) below what was measured, and the stated range covers the measured number.
By their numbers in this assay, from the lowest: compound 1; then compounds 4 and 2 (each within the scatter of the next); then compound 3.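

In this assay the change from 4-methylpiperazin-1-yl to 2-(4-methylpiperazin-1-yl)ethyl gives a 3.7-fold higher number from compound 1 to compound 4 (0.56 log units; beyond the scatter) and so shows that chain length alone moves the number at this position, on a saturated chain carbon, four bonds along the chain from an aromatic nitrogen. Going by these compounds alone, the ring at the chain end stays the same, as do the counts of hydrogen-bond donors and acceptors, so this is the first measured step that isolates chain length, and it is modest beside a 14-fold higher number from compound 2 to compound 3 (1.14 log units; beyond the scatter) in the same assay. Nothing available bears on why the longer chain gives the higher number.

Within the data shown here, with only two chain lengths carrying the methylpiperazine, it remains open whether the number would keep rising with a longer chain such as 6-(4-methylpiperazin-1-yl)hexyl, or whether the trend would hold on a shorter chain. Going by these compounds, it also remains open whether the same lengthening would have a similar effect with a morpholine or a dimethylamino group at the chain end in place of the methylpiperazine.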